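Adding a Methyl Branch to a Short Nucleotide Side Chain

The source may report more compounds than this note shows. Statements on the series, on what has been measured and on what is new or still open speak of the compounds shown alone.

In a functional assay on L1210 cells (Mus musculus) for cytotoxicity (on this read-out lower numbers stand for stronger inhibition and higher numbers for weaker inhibition), compound 2, `CCc1cn([C@@H]2O[C@@H]3COP(=O)(O)O[C@H]3[C@H]2O)c(=O)nc1N`, reaches only a limit of the assay, > 200 ug/mL. Among the compounds with values here, its one measured neighbour, compound 1, `CCCCCCCCc1cn([C@@H]2O[C@@H]3COP(=O)(O)O[C@H]3[C@H]2O)c(=O)nc1N`, also gives a limit in this assay, > 200 ug/mL. The step that the two limits leave unreadable from compound 1 to compound 2 is thus unreadable: both values rest at the same edge, (the limit of > 200 ug/mL in this assay, at which 2 of the 2 values shown sit), so neither direction nor size can be taken from them. Compound 3, `CC(C)c1cn([C@@H]2O[C@@H]3COP(=O)(O)O[C@H]3[C@H]2O)c(=O)nc1N`, differs from compound 2 by methyl in place of hydrogen on a saturated chain carbon bound to an aromatic carbon and a saturated chain carbon. Within the data shown here, no measured step shows what this change does, and the only comparison available, hexyl against hydrogen, ends on both sides at the same limit. In this assay the expected step is a step that the limit leaves unreadable from compound 2 to compound 3, meaning no movement beyond the scatter. Compound 3 is therefore estimated to give about 300 ug/mL, within a range of 150 ug/mL to 1000 ug/mL, most likely reported once more as a limit only.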

Compound 3, concentration for 50% inhibition: > 200 ug/mL
Compound 3: no number, only a limit; the forecaster's own chance of this, stated with the estimate: 85%; the middle value is on the limit's open side.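

Compound 1, compound 2 and compound 3 all rest at the same edge of this assay, so no step among them can be read: the limit of > 200 ug/mL in this assay, at which 3 of the 3 values shown sit.

The compounds shown leave open how strong each one really is, and so whether octyl, ethyl and isopropyl differ at all on this read-out.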